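A few compounds are considered here, and "the series" means these few. Any claim that something is new, unique, unknown or untested is made for them only; others in the source may bear on it.

Among the measured compounds shown here, in a functional assay on HeLa cells (Homo sapiens) for cytotoxicity, with a stated time of 72 h (on this read-out lower numbers stand for stronger inhibition and higher numbers for weaker inhibition), compound 3 `O=Cc1c(-c2ccc(F)cc2)nc2sc(Cc3ccc(Cl)cc3)nn12` gives 20000 nM, the only number among the three measured compounds. Compound 1 `Fc1ccc(-c2cn3nc(Cc4ccc(Cl)cc4)sc3n2)cc1` sits at a limit of the assay, > 250000 nM. Compound 2 `Clc1ccc(Cc2nn3c(Br)c(-c4ccc(Cl)cc4)nc3s2)cc1` also sits at a limit, > 250000 nM. For the measured compounds named here, the one measured step, an at least 12-fold lower number from compound 1 to compound 3 (1.09 log units; beyond the scatter), is large, and the limit of > 250000 nM in this assay, at which 2 of the 3 values shown sit, is where two of the three values rest. Compound 4 `O=Cc1c(-c2ccc(Cl)cc2)nc2sc(Cc3ccc(Cl)cc3)nn12` differs from compound 3 by chloro in place of fluoro on an aromatic carbon. Going by the values given here, no measured step exchanges one halogen for another on this ring, so the comparison rests on compound 3 alone, and no shift beyond the scatter is expected, no change at the digits printed from compound 3 to compound 4 (within the scatter). Compound 4 is therefore estimated at 20000 nM, within 7000 nM to 60000 nM.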

Compound 4, half-maximal inhibitory concentration: 16000 nM
Compound 4: middle estimate off by 1.3-fold (0.10 log units), on the high side; measured number inside the range.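

Chloro in place of fluoro on the aromatic ring gives a 1.3-fold lower number from compound 3 to compound 4 (0.10 log units; within the scatter), so in this assay 4-fluorophenyl and 4-chlorophenyl cannot be told apart at this place. Formyl in place of bromo gives an at least 15-fold lower number from compound 2 to compound 4 (1.19 log units; beyond the scatter), so formyl now goes with a lower number in a compound carrying 4-chlorophenyl as well as one carrying 4-fluorophenyl. The two compounds without formyl rest at the same limit: the limit of > 250000 nM in this assay, at which 2 of the 4 values shown sit.

Open, from the compounds shown here alone, is whether a carboxylic acid, a hydroxymethyl or an amine in place of formyl would also lower the number. Also open, going by these compounds, is how a methoxy in place of the halogen would read.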